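Pyridine series: chlorophenyl position change in the cytotoxicity assay

The compounds below may be only part of what the source reports. "The series", "measured", "known", "first", "only" and "open" are said of these compounds alone.

Measured compounds:
- compound 1 `Oc1ccc(-c2cc(-c3cccs3)nc(-c3ccccc3Cl)c2)cc1` — 4190 nM
- compound 2 `Oc1ccc(-c2cc(-c3cccc(Cl)c3)nc(-c3ccco3)c2)cc1` — 5750 nM
- compound 3 `Oc1ccc(-c2cc(-c3ccco3)nc(-c3ccccc3Cl)c2)cc1` — 5300 nM

All three numbers come from a functional assay on DU-145 cells (Homo sapiens) for cytotoxicity, read by CCK-8 assay and cell counting, with a stated time of 2 days; a lower number here means a stronger inhibitor, a higher number a weaker inhibitor. Compound 3 sits second highest of the three, with compound 2 nearest and compound 1 furthest; both gaps lie within the scatter, so no order among the three can be read. The step of a 1.3-fold higher number from compound 1 to compound 3 (0.10 log units; within the scatter) and the step of a 1.1-fold lower number from compound 2 to compound 3 (0.04 log units; within the scatter) are each within the scatter: neither the exchange of the five-membered heteroaryl nor moving the chlorine from the 3-position to the 2-position of the chlorophenyl group changed the number in a meaningful way.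

Compound 4 `Oc1ccc(-c2cc(-c3ccc(Cl)cc3)nc(-c3ccco3)c2)cc1` is not yet measured. Relative to compound 3 the change is 4-chlorophenyl in place of 2-chlorophenyl on an aromatic carbon. Within the data shown here, the only step that bears on it is the chlorine move a 1.1-fold lower number from compound 2 to compound 3 (0.04 log units; within the scatter), which was within the scatter; no measured step covers the 4-chlorophenyl group itself. On this basis compound 4 is expected to stay within the scatter of compound 3, a step of a 1.1-fold lower number from compound 3 to compound 4 (0.03 log units; within the scatter). The estimate for compound 4 in this assay is 5000 nM, with a range from 2500 nM to 10000 nM.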

Compound 4, half-maximal inhibitory concentration: 7280 nM
Compound 4: the middle estimate sits 1.5-fold (0.16 log units) below what was measured; low and high end bracket the measured number.
By their numbers in this assay, from the lowest: compounds 1, 3, 2 and 4 (each within the scatter of the next).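

With compound 4, the chlorine has now been placed at the 2-, 3- and 4-positions of the chlorophenyl group with the furan-2-yl group kept, on the aromatic carbon next to the ring nitrogen. In this assay, the 4-chlorophenyl group gives a 1.4-fold higher number from compound 3 to compound 4 (0.14 log units; within the scatter) and a 1.3-fold higher number from compound 2 to compound 4 (0.10 log units; within the scatter), both within the scatter, so chlorine position does not separate compound 2, compound 3 and compound 4 here. Nothing available explains the values of these three isomers.

Still open, going by these compounds, is whether an amine or a carboxylic acid in place of the chlorine would move the number beyond the scatter. The contribution of the 4-hydroxyphenyl group, common to all four compounds, also cannot be judged from this set.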